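The compounds below may be only part of what the source reports. "The series", "measured", "known", "first", "only" and "open" are said of these compounds alone.

Within the data shown here, in an ADME assay on MT4 cells (Homo sapiens) for cytotoxicity, read by MTT assay (a higher number here means that more compound is tolerated, a lower number that less compound is tolerated), compound 2 `Cc1ccc(N(C(=O)c2c(Cl)cccc2Cl)C(=S)OCCN2C(=O)c3ccccc3C2=O)cc1` gives 22000 nM, the only actual number so far. Compound 1 `Cc1ccc(N(C(=O)c2ccccc2C)C(=S)OCCN2C(=O)c3ccccc3C2=O)cc1` reads > 100000 nM, which is a limit of this assay and not a number. The next compound, compound 3 `Cc1ccc(N(C(=O)c2ccc([N+](=O)[O-])cc2Cl)C(=S)OCCN2C(=O)c3ccccc3C2=O)cc1`, keeps the shared core and changes only the aryl group: 2-chloro-4-nitrophenyl in place of 2,6-dichlorophenyl on a carbonyl carbon. In words, 2-chloro-4-nitrophenyl takes the place of 2,6-dichlorophenyl on a carbonyl carbon. Among the measured compounds shown here, only one measured step bears on this place, an at least 4.5-fold lower number from compound 1 to compound 2 (0.65 log units; beyond the scatter), when 2,6-dichlorophenyl replaced 2-methylphenyl on the same carbonyl carbon. That single step is a thin guide, and it does not cover a nitro group, so no clear direction can be drawn from it for this assay. The expected step is a 1.1-fold higher number from compound 2 to compound 3 (0.06 log units; within the scatter), with nothing beyond the scatter foreseen. For compound 3 the estimated value is 25000 nM, with an expected range from 8000 nM to 80000 nM.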

Compound 3, half-maximal cytotoxic concentration: 17000 nM
Beside the measured number, compound 3's estimate is 1.5-fold (0.17 log units) above it; the range from low to high includes it.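

In this assay, exchanging the aryl group on a carbonyl carbon whose other neighbour is the amide-type nitrogen gives a 1.3-fold lower number from compound 2 to compound 3 (0.11 log units; within the scatter), so 2-chloro-4-nitrophenyl and 2,6-dichlorophenyl cannot be told apart here, even though one carries a nitro group and the other a second chlorine. Against 2-methylphenyl, the new group gives an at least 5.8-fold lower number from compound 1 to compound 3 (0.76 log units; beyond the scatter), so a second chlorine-bearing aryl group now stands apart from the methyl-bearing one. The reading for compound 1 is a limit and not a number, so the true size of that step stays unknown: the limit of > 100000 nM in this assay, at which 1 of the 3 values shown sits.

Open, going by these compounds, is how a 4-nitrophenyl group without chlorine, a 2-chlorophenyl group or a plain phenyl group would read at this carbonyl carbon, which would separate the part played by the chlorine from that of the nitro group. Also open, on these data alone, is whether an amine on this ring, or a longer chain elsewhere on the shared core, would shift the tolerated concentration.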